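Replacing 3-ethynylphenyl with 3,4-dichlorophenyl on the amide nitrogen

The compounds below may be only part of what the source reports. "The series", "measured", "known", "first", "only" and "open" are said of these compounds alone.

In a functional assay on A549 cells (Homo sapiens) for antiproliferative activity, read by MTT assay, with a stated time of 48 h (on this read-out lower numbers stand for stronger inhibition and higher numbers for weaker inhibition), compound 1 (`O=C(CCCCCC(=O)Nc1ccc(O)c(C(=O)Nc2cccc(C(F)(F)F)c2)c1)NO`) gives 25700 nM and compound 2 (`C#Cc1cccc(NC(=O)c2cc(NC(=O)CCCCCC(=O)NO)ccc2O)c1`) gives 76200 nM as the higher of the two numbers. For the measured compounds named here, the one measured step (a 3.0-fold higher number from compound 1 to compound 2 (0.47 log units; beyond the scatter)) is modest and beyond the scatter, with ethynyl in place of trifluoromethyl on an aromatic carbon. Compound 3 (`O=C(CCCCCC(=O)Nc1ccc(O)c(C(=O)Nc2ccc(Cl)c(Cl)c2)c1)NO`) differs from compound 2 in one place (3,4-dichlorophenyl in place of 3-ethynylphenyl on an amide-type nitrogen), with 3,4-dichlorophenyl in place of 3-ethynylphenyl on an amide-type nitrogen. Like compound 1, compound 3 lacks the ethynyl group, but no measured compound carries 3,4-dichlorophenyl, so that step read in reverse is only an indirect guide. A modest move to a lower number is therefore expected (a 2.4-fold lower number from compound 2 to compound 3 (0.38 log units; beyond the scatter)), similar in size to the measured step. The estimated value in this assay for compound 3 is 32000 nM (range 11000 nM to 85000 nM).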

Compound 3, half-maximal inhibitory concentration: 17800 nM
Estimate against measurement, compound 3: 1.8-fold (0.25 log units) above; measured number inside the range.
By their numbers in this assay, from the lowest: compounds 3 and 1 (each within the scatter of the next); then compound 2.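

In this assay, 3,4-dichlorophenyl in place of 3-ethynylphenyl on the amide-type nitrogen gives a 4.3-fold lower number from compound 2 to compound 3 (0.63 log units; beyond the scatter) and is a second change at this position that moves away from the number of compound 2. Set against 3-(trifluoromethyl)phenyl, the same group gives a 1.4-fold lower number from compound 1 to compound 3 (0.16 log units; within the scatter) and so cannot be separated from it on this read-out. Among these three compounds, compound 2 therefore stands apart, while compound 1 and compound 3 form one level despite carrying different aryl groups. Nothing available bears on the reason for these differences.

The compounds shown leave open how a phenyl group carrying an amine or a carboxylic acid would read at this position. They also leave open whether a longer chain would keep the level shared by compound 1 and compound 3.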